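This account rests on a few compounds, and the source may have more. Where it says the series, first, only, none or still open, it means among the compounds named here.

Measured compounds:
compound 1, `CC(C)c1c(C(=O)N(C)Cc2cccc(F)c2)nn(-c2ccc(F)cc2)c1CC[C@@H](O)C[C@@H](O)CC(=O)O` — in an assay on microsomes from liver for inhibition of 3-hydroxy-3-methylglutaryl-coenzyme A reductase (Rattus norvegicus) (a higher number here means a weaker inhibitor, a lower number a stronger inhibitor), compound 1 gives 4.1 nM
compound 2, `Cc1ccccc1CNC(=O)c1nn(-c2ccc(F)cc2)c(OC[C@@H](O)C[C@@H](O)CC(=O)O)c1C(C)C` — in this assay compound 2 gives 17 nM

Compound 2 holds the higher of the two numbers; compound 1 gives 4.1 nM, a lower number, and the gap between the two lies beyond the scatter. Compound 3, `CC(C)c1c(C(=O)NCc2ccc(Cl)cc2)nn(-c2ccc(F)cc2)c1OC[C@@H](O)C[C@@H](O)CC(=O)O`, differs from compound 2 by 4-chlorophenyl in place of 2-methylphenyl on a saturated chain carbon bound to an amide-type nitrogen. Nothing measured here shows how such a swap counts, so the step expected from compound 2 to compound 3 is small and in no firm direction, a 1.4-fold lower number from compound 2 to compound 3 (0.15 log units; within the scatter), within the scatter. Compound 3 is therefore expected to give 12 nM, with a range from 5 nM to 30 nM.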

Compound 3, half-maximal inhibitory concentration: 6.7 nM
Compound 3: the middle estimate sits 1.8-fold (0.25 log units) above what was measured; measured number inside the range.
By their numbers in this assay, from the lowest: compounds 1 and 3 (each within the scatter of the next); then compound 2.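

At this place, on a saturated chain carbon bound to an amide-type nitrogen, the aryl group matters: in this assay putting 4-chlorophenyl in place of 2-methylphenyl gives a 2.5-fold lower number from compound 2 to compound 3 (0.40 log units; beyond the scatter) and so moves the number modestly. The two rings have the same count of heavy atoms, so the change lies in what each ring carries and where. Nothing measured here gives a reason for this step.

The swap changes both the substituent and its place on the ring, and the compounds shown do not separate the two. Unsubstituted phenyl, 4-methylphenyl and 2-chlorophenyl would each help to pull them apart.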